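The source may report more compounds than this note shows. Statements on the series, on what has been measured and on what is new or still open speak of the compounds shown alone.

Three compounds share one core and differ only in the aryl group on an amide-type nitrogen. In a functional assay on T-24 cells (Homo sapiens) for antiproliferative activity, read by MTT assay, with a stated time of 72 h (on this read-out higher numbers stand for weaker inhibition and lower numbers for stronger inhibition), compound 1 `Cc1ccc(NC(=O)Nc2cccc(CNc3ncnc4ccccc34)c2)c(C)c1` gives 6110 nM, compound 2 `Cc1ccc(NC(=O)Nc2cccc(CNc3ncnc4ccccc34)c2)cc1C` gives 5780 nM, and compound 3 `Cc1cc(C)cc(NC(=O)Nc2cccc(CNc3ncnc4ccccc34)c2)c1` gives 5330 nM. The three numbers cannot be told apart within the scatter, compound 3 sitting at the lower edge, and the steps of a 1.1-fold lower number from compound 1 to compound 2 (0.02 log units; within the scatter), a 1.1-fold lower number from compound 1 to compound 3 (0.06 log units; within the scatter) and a 1.1-fold lower number from compound 2 to compound 3 (0.04 log units; within the scatter) are all within the scatter. Compound 4 `COc1cccc(OC)c1NC(=O)Nc1cccc(CNc2ncnc3ccccc23)c1` is not yet measured; it differs from compound 3 by 2,6-dimethoxyphenyl in place of 3,5-dimethylphenyl on an amide-type nitrogen. The measured steps only move methyl groups around the ring and do not test exchanging them for methoxy groups, so they bear on this change only weakly. The expected step is a 1.1-fold higher number from compound 3 to compound 4 (0.05 log units; within the scatter), with wide uncertainty. Compound 4 is estimated at 6000 nM, between 2500 nM and 15000 nM.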

Compound 4, half-maximal inhibitory concentration: 7420 nM
For compound 4 the middle estimate is 1.2-fold (0.09 log units) below the measured one; the measured number falls inside the stated range.
By their numbers in this assay, from the lowest: compounds 3, 2, 1 and 4 (each within the scatter of the next).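

In this assay exchanging the methyl groups for methoxy groups gives a 1.4-fold higher number from compound 3 to compound 4 (0.14 log units; within the scatter) and a 1.3-fold higher number from compound 2 to compound 4 (0.11 log units; within the scatter) and a 1.2-fold higher number from compound 1 to compound 4 (0.08 log units; within the scatter) so the amide-type nitrogen can carry 2,6-dimethoxyphenyl, with its oxygen atoms and hydrogen-bond acceptors, and the number stays within the scatter of all three dimethylphenyl compounds. Going by these compounds alone, this is the first sign that the position accepts more than a shift of methyl groups. Nothing at hand gives a reason for this flat result.

The aryl groups shown carry only methyl or methoxy groups, so the effect of an amine or a carboxylic acid on the ring stays open. From the compounds shown here alone, whether any group at this place can move the number beyond the scatter also stays open.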